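The source may report more compounds than this note shows. Statements on the series, on what has been measured and on what is new or still open speak of the compounds shown alone.

Measured so far:
Compound 1 `COc1cc(N/C=C\C(=O)c2cn(-c3ccccc3)nc2-c2ccccc2)cc(OC)c1OC` gives 36200 nM in an ADME assay on HaCaT cells (Homo sapiens) for antiproliferative activity, read by MTT assay, with a stated time of 48 h; a lower number here means a stronger inhibitor, a higher number a weaker inhibitor.
Compound 2 `COc1cc(N/C=C\C(=O)c2cn(-c3ccccc3)nc2-c2ccc(Cl)cc2)cc(OC)c1OC` gives 46600 nM in this assay.
Compound 3 `COc1ccc(N/C=C\C(=O)c2cn(-c3ccccc3)nc2-c2cc(OC)c(OC)c(OC)c2)cc1` gives only a limit, > 50000 nM in this assay.

Compound 3 stands at the edge of what this assay can report: its value is a limit of > 50000 nM in this assay, at which 1 of the 3 values shown sits, and not a number, so its true position is not known. Compound 4 `COc1cc(N/C=C\C(=O)c2cn(-c3ccccc3)nc2-c2cc(OC)c(OC)c(OC)c2)cc(OC)c1OC` differs from it in one place: 3,4,5-trimethoxyphenyl in place of 4-methoxyphenyl on an amine nitrogen. Among the compounds with values here, the only measured single step, a 1.3-fold higher number from compound 1 to compound 2 (0.11 log units; within the scatter), alters a different part of the shared core, so no measured step covers the change on the amine nitrogen. Compound 1 already carries the 3,4,5-trimethoxyphenyl on the amine nitrogen and gives 36200 nM, and compound 2 gives 46600 nM. All three measured compounds sit in the weak range of this assay. No step beyond the scatter is therefore expected from compound 3 to compound 4. The estimated step is an at least 1.1-fold lower number from compound 3 to compound 4 (0.04 log units; that floor lies within the scatter). Compound 4 is expected to give about 45000 nM, within a range from 20000 nM to 100000 nM, with a fair chance that only a limit is reported again.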

Compound 4, half-maximal inhibitory concentration: 20900 nM
Estimate against measurement, compound 4: 2.2-fold (0.33 log units) above, and the stated range covers the measured number.
By their numbers in this assay, from the lowest: compounds 4, 1 and 2 (each within the scatter of the next, the first and the last beyond it). At a limit, above all of these: compound 3.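

On the amine nitrogen, 3,4,5-trimethoxyphenyl in place of 4-methoxyphenyl turns a limit into a measured number in this assay, with an at least 2.3-fold lower number from compound 3 to compound 4 (0.37 log units; beyond the scatter), so this position responds to the change. The value of compound 3 is a limit and not a number, so this step gives only a minimum size: the limit of > 50000 nM in this assay, at which 1 of the 4 values shown sits. With 3,4,5-trimethoxyphenyl already on the amine nitrogen, the same group on an aromatic carbon in place of 4-chlorophenyl gives a 2.2-fold lower number from compound 2 to compound 4 (0.35 log units; beyond the scatter), while in place of phenyl it gives a 1.7-fold lower number from compound 1 to compound 4 (0.24 log units; within the scatter).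

On these data alone, the full size of the step on the amine nitrogen stays open, as does which of the three methoxy groups matters for it. Also open, as far as these compounds go, is how a hydroxyl or a dimethylamino group on that phenyl ring would read in this assay.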